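From hydroxy to methoxy on compound 2

The source may hold more compounds than are shown below. What is called first, only, known or untested is meant among the compounds shown, and "the series" means these compounds.

- Compound 1 `CO[C@]1(C)/C=C/C(=O)/C(CO)=C\C[C@](C)(CCC=C(C)C)/C=C/[C@H]1OC(=O)C=C(C)C` gives 15800 nM
- Compound 2 `CC(C)=CCC[C@]1(C)/C=C/[C@@H](OC(=O)C=C(C)C)[C@](C)(O)/C=C/[C@H](O)/C(CO)=C\C1` gives > 40000 nM (a limit)
- Compound 3 `CC(C)=CCC[C@]1(C)/C=C/[C@@H](OC(=O)C=C(C)C)[C@](C)(O)/C=C/C(=O)/C(C(=O)N2CCCC2)=C\C1` gives 14900 nM

Among the measured compounds shown here, all three values come from a functional assay on SMMC-7721 cells (Homo sapiens) for antiproliferative activity, read by MTT assay, with a stated time of 48 h (a higher number here means a weaker inhibitor, a lower number a stronger inhibitor), and compound 2 is the one without a number. In this assay compound 2 stands at > 40000 nM, which is a limit of the assay. Compound 1 gives 15800 nM and compound 3 gives 14900 nM, so these two sit within the scatter of each other.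

Compound 4 `CO[C@H]1/C=C/[C@@](C)(O)[C@H](OC(=O)C=C(C)C)/C=C/[C@@](C)(CCC=C(C)C)C/C=C\1CO` has not yet been measured. It is compound 2 with one change (methyl in place of hydrogen on an oxygen on a saturated carbon), methyl in place of hydrogen on an oxygen on a saturated carbon, or hydroxy to methoxy. For the measured compounds named here, no measured pair shows this change alone. The expectation therefore starts from compound 2 at the limit of > 40000 nM and is cautious. In this assay only a small move toward stronger inhibition is expected, possibly none beyond the scatter, and the assay may again report only a limit. The expected step is an at least 1.3-fold lower number from compound 2 to compound 4 (0.12 log units; that floor lies within the scatter) on this estimate. For compound 4 the estimated value is 30000 nM with an expected range from 13000 nM to 60000 nM in this reading.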

Compound 4, half-maximal inhibitory concentration: 38100 nM
For compound 4 the middle estimate is 1.3-fold (0.10 log units) below the measured one; low and high end bracket the measured number.
By their numbers in this assay, from the lowest: compounds 3 and 1 (each within the scatter of the next); then compound 4. At a limit, above all of these: compound 2.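

In this assay methyl in place of hydrogen on an oxygen on a saturated carbon gives an at least 1.0-fold lower number from compound 2 to compound 4 (0.02 log units; that floor lies within the scatter) and so yields a measured number where there had been only a limit. The change from hydroxy to methoxy is therefore not shown to move the value beyond the scatter, although it is also not shown to leave the value unchanged. The true size of the step stays unknown because its starting point is a limit and not a number: the limit of > 40000 nM in this assay, at which 1 of the 4 values shown sits.

The compounds shown leave open how an ethoxy or benzyloxy group, or an amine, would read at this place in this assay on the same core. They also leave open whether hydroxy to methoxy gives a step of readable size when it starts from a compound with a measured value.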